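A few compounds are considered here, and "the series" means these few. Any claim that something is new, unique, unknown or untested is made for them only; others in the source may bear on it.

Measured compounds in an assay on isolated protein for inhibition of alpha-ketoglutarate-dependent dioxygenase alkB homolog 3 (Homo sapiens), read by polymerase chain reaction, with a stated time of 1 h; on this read-out lower numbers stand for stronger inhibition and higher numbers for weaker inhibition:
- compound 1 `Cc1[nH]n(-c2nc3cc(-c4ccccc4)ccc3[nH]2)c(=O)c1Cc1ccccc1`: 810 nM
- compound 2 `Oc1c(-c2ccccc2)c(-c2ccccc2)nn1-c1nc2cc(Cl)ccc2[nH]1`: 2000 nM
- compound 3 `Cc1c(-c2ccccc2)[nH]n(-c2nc3ccccc3[nH]2)c1=O`: limit, > 10000 nM

Compound 2 stands at the higher of the two numbers reported in this assay; its nearest neighbour, compound 1, gives 810 nM, a gap that lies beyond the usual scatter. For compound 3 this assay reports only a limit, > 10000 nM, which is the limit of this assay the limit of > 10000 nM in this assay, at which 1 of the 3 values shown sits, rather than a number.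

Compound 4 `Cc1ccc2[nH]c(-n3nc(-c4ccccc4)c(-c4ccccc4)c3O)nc2c1` has not been measured in this assay. It differs from compound 2 in one place: methyl in place of chloro on an aromatic carbon. The two groups are each a single heavy atom, neither carries a hydrogen-bond donor or acceptor, and neither brings a charge. Among the compounds with values here, no step between measured compounds covers this exchange, and compound 1 and compound 3 differ from compound 2 in several places at once, so they give no guidance on it.

The change is therefore expected to move the number little, with no step beyond the scatter from compound 2 to compound 4, a 1.3-fold higher number from compound 2 to compound 4 (0.10 log units; within the scatter). Compound 4 is estimated to give 2500 nM in this assay, within a range from 1000 nM to 7000 nM.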

Compound 4, half-maximal inhibitory concentration: 5800 nM
Beside the measured number, compound 4's estimate is 2.3-fold (0.37 log units) below it; the measured number falls inside the stated range.
By their numbers in this assay, from the lowest: compound 1; then compound 2; then compound 4. At a limit, above all of these: compound 3.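

In this assay, the exchange of chloro for methyl, on an aromatic carbon of the six-membered aromatic ring of carbon only, is the one change among the compounds shown that can be read on its own, and it gives a 2.9-fold higher number from compound 2 to compound 4 (0.46 log units; beyond the scatter). This shows that the number responds to what sits at this place, even though the two groups match in every feature counted for them: heavy atoms, hydrogen-bond donors, hydrogen-bond acceptors and net charge. The step is modest and rests on a single pair, and nothing measured here accounts for it.

On these data alone, whether a bare hydrogen, fluoro, methoxy, an amine or a carboxylic acid at this place would move the number further, and in which direction, remains open. As far as these compounds go, compound 1 and compound 3 differ from compound 2 in several places at once, so it also remains open whether the exchange of chloro for methyl would have a similar effect on the core of either compound.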